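Swapping a Methoxyphenyl for a Chlorophenyl on the Shared Core

The compounds below may be only part of what the source reports. "The series", "measured", "known", "first", "only" and "open" are said of these compounds alone.

Of the compounds shown here, two have been measured in a functional assay for agonist activity at G protein-coupled receptor 88 (Homo sapiens), read by HTRF and cAMP accumulation; on this read-out higher numbers stand for an effect only at larger amounts of compound and lower numbers for an effect already at smaller amounts. Compound 1 `CC(C)C[C@H](N)CN(C(=O)[C@@H]1C[C@H]1c1ccccc1)c1ccc(C2=CCCCCC2)cc1` gives 2100 nM in this assay. Compound 2 `COc1cccc(-c2ccc(N(C[C@@H](N)CC(C)C)C(=O)[C@@H]3C[C@H]3c3ccccc3)cc2)c1` gives 1100 nM in this assay, which is the lower of the two numbers; the change a 1.9-fold lower number from compound 1 to compound 2 (0.28 log units; within the scatter) is however too small to count as a real difference, so the two compounds cannot be ranked against each other. Compound 3 `CC(C)C[C@H](N)CN(C(=O)[C@@H]1C[C@H]1c1ccccc1)c1ccc(-c2ccc(Cl)cc2)cc1` has not yet been measured. It differs from compound 2 in one place: 4-chlorophenyl in place of 3-methoxyphenyl on an aromatic carbon. Among the measured compounds shown here, no measured step bears directly on this exchange. For the measured compounds named here, the only step available is a 1.9-fold lower number from compound 1 to compound 2 (0.28 log units; within the scatter), where a different group at the same aromatic carbon was exchanged without a change beyond the scatter. On that basis no change beyond the scatter is expected for compound 3 in this assay either, and the step of a 1.2-fold higher number from compound 2 to compound 3 (0.07 log units; within the scatter) is estimated to stay within it. Compound 3 is therefore expected to give about 1300 nM in this assay, with a likely range from 400 nM to 4500 nM.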

Compound 3, half-maximal effective concentration: 640 nM
Compound 3: middle estimate off by 2.0-fold (0.31 log units), on the high side; the measured number falls inside the stated range.
By their numbers in this assay, from the lowest: compounds 3, 2 and 1 (each within the scatter of the next, the first and the last beyond it).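

At this aromatic carbon, para to a large group, this assay shows a 1.7-fold lower number from compound 2 to compound 3 (0.24 log units; within the scatter) and so does not separate 3-methoxyphenyl from 4-chlorophenyl. The more informative result is a 3.3-fold lower number from compound 1 to compound 3 (0.52 log units; beyond the scatter). Among the compounds shown here, it is the first step here to pass beyond the scatter, showing that the group at this position can change the number, though only modestly, when 4-chlorophenyl takes the place of cyclohept-1-en-1-yl. Compound 2 remains within the scatter of both other compounds, and no accompanying measurement gives a reason for the step from compound 1 to compound 3.

The exchange between compound 2 and compound 3 alters both the substituent and its place on the ring, so 3-chlorophenyl and 4-methoxyphenyl would be needed to tell whether the chlorine or its position matters more. From the compounds shown here alone, it also remains open how this position would respond to a ring carrying an amine or a carboxylic acid, or to a pyridine ring in place of the phenyl ring.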